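Lengthening the Hydroxyalkyl Chain on the Shared Core

The source may hold more compounds than are shown below. What is called first, only, known or untested is meant among the compounds shown, and "the series" means these compounds.

Compound 1 `CCN(CC)CCn1c(N)c(-c2nc3ccccc3[nH]2)c2nc(C#N)c(C#N)nc21` gives 2490 nM in a functional assay on K562 cells (Homo sapiens) for antiproliferative activity, read by MTT assay, with a stated time of 48 h; on this read-out higher numbers stand for weaker inhibition and lower numbers for stronger inhibition. Compound 2 `N#Cc1nc2c(-c3nc4ccccc4[nH]3)c(N)n(CCO)c2nc1C#N` is reported in this assay only as a limit of the assay, > 50000 nM. Going by the values given here, the single measured step, an at least 20-fold higher number from compound 1 to compound 2 (1.30 log units; beyond the scatter), ends at the limit of > 50000 nM in this assay, at which 1 of the 2 values shown sits. Compound 3 `N#Cc1nc2c(-c3nc4ccccc4[nH]3)c(N)n(CCCO)c2nc1C#N` differs from compound 2 by hydroxymethyl in place of hydroxy on a saturated chain carbon, two bonds along the chain from an aromatic nitrogen. Among the compounds with values here, no measured step covers this change directly; the one measured step shows only that the hydroxy chain already sits at the limit. The step expected from compound 2 to compound 3 is a number no higher from compound 2 to compound 3 (the limit leaves the size open). Compound 3 is therefore estimated at 50000 nM in this assay, between 15000 nM and 160000 nM, quite possibly again a limit.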

Compound 3, half-maximal inhibitory concentration: > 50000 nM
Compound 3 ended at the assay's limit; the forecaster's own chance of this, stated with the estimate: 65%; the middle value sits exactly at the limit.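

In this assay compound 3 gives > 50000 nM, and this is a limit, not a number. Going from 2-hydroxyethyl to 3-hydroxypropyl thus brings no readable value back, and the diethylamino chain stays well apart, with an at least 20-fold higher number from compound 1 to compound 3 (1.30 log units; beyond the scatter). The step between the two hydroxy compounds cannot be read, so any effect of hydroxyalkyl chain length stays hidden: the limit of > 50000 nM in this assay, at which 2 of the 3 values shown sit.

On these data alone, it remains open whether a longer chain ending in an amine other than diethylamino, or a chain bearing a carboxylic acid, would give a value within the measurable range.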